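A pentyl chain gives way to an ester-bearing substituent

A few compounds are considered here, and "the series" means these few. Any claim that something is new, unique, unknown or untested is made for them only; others in the source may bear on it.

Compound 1 `CCCCCNc1cccc2c(S(=O)(=O)Nc3onc(C)c3C)cccc12` holds the lowest number among the three measured compounds in an assay on VSM-A10 cells for antagonist activity at Endothelin-1 receptor (Rattus norvegicus) (a higher number here means a weaker inhibitor, a lower number a stronger inhibitor), where compound 1 gives 80 nM. Compound 2 `Cc1noc(NS(=O)(=O)c2ccc(F)cc2)c1C` gives 1000 nM, and compound 3 `Cc1noc(NS(=O)(=O)c2ccc(NCC(=O)O)cc2)c1C` gives 12000 nM. Among the compounds with values here, the one measured step, a 12-fold higher number from compound 2 to compound 3 (1.08 log units; beyond the scatter), replaces fluoro with (carboxymethyl)amino and weakens inhibition sharply. Compound 4 `CCOC(=O)C(C)Nc1cccc2c(S(=O)(=O)Nc3onc(C)c3C)cccc12` differs from compound 1 by 1-(ethoxycarbonyl)ethyl in place of pentyl on a nitrogen on an aromatic ring. Within the data shown here, the step from compound 2 to compound 3 bears only loosely on this change, since it concerns a different core and a carboxylic acid rather than an ester, yet it is the sole guide and points toward a weaker inhibitor. Compound 4 is therefore expected to give 250 nM, within 80 nM to 800 nM, a step of a 3.1-fold higher number from compound 1 to compound 4 (0.49 log units; beyond the scatter).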

Compound 4, half-maximal inhibitory concentration: 400 nM
Compound 4: middle estimate off by 1.6-fold (0.20 log units), on the low side; the range from low to high includes it.
By their numbers in this assay, from the lowest: compound 1; then compound 4; then compound 2; then compound 3.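

On the core of compound 1, the change at the nitrogen on the aromatic ring can now be read directly: in this assay, 1-(ethoxycarbonyl)ethyl in place of pentyl gives a 5.0-fold higher number from compound 1 to compound 4 (0.70 log units; beyond the scatter) and leaves a modest loss of inhibition rather than the large one seen on the other core. Nothing shown here explains this step. Still open, as far as these compounds go, is which part of the 1-(ethoxycarbonyl)ethyl group carries the step, and whether a carboxylic acid on this same chain, or a chain longer than pentyl, would move the number further.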